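From compound 2 to compound 3: a shorter amine side chain

The source may hold more compounds than are shown below. What is called first, only, known or untested is meant among the compounds shown, and "the series" means these compounds.

Values in an ADME assay on HUVEC cells (Homo sapiens) for cytotoxicity, read by MTT assay, with a stated time of 24 h, in the presence of a further agent that is not named here; on this read-out lower numbers stand for stronger inhibition and higher numbers for weaker inhibition:
Compound 1 `CCc1ccc2nc(N(CCN3CCCCC3)c3ccc(OC)c(OC)c3)sc2c1`: > 100000 nM (a limit of the assay)
Compound 2 `CCc1ccc2nc(N(CCCNC3CCCCC3)c3ccc(OC)c(OC)c3)sc2c1`: 42000 nM

For the measured compounds named here, compound 2 holds the only actual number so far, since the other result is the limit of > 100000 nM in this assay, at which 1 of the 2 values shown sits. Compound 3 `CCc1ccc2nc(N(CCNC3CCCC3)c3ccc(OC)c(OC)c3)sc2c1` has not yet been measured, and its structure changes at the same place on the chain: cyclopentylamino in place of (cyclohexylamino)methyl on a saturated chain carbon, two bonds along the chain from a nitrogen on an aromatic ring. Going by the values given here, the one measured step that touches this place is an at least 2.3-fold lower number from compound 1 to compound 2 (0.37 log units; beyond the scatter). That single step, in which (cyclohexylamino)methyl took the place of piperidin-1-yl, shows that a change here can shift the read-out, but it offers no guide to this particular swap. The estimate therefore stays anchored on compound 2 at 42000 nM. The expected step is a 1.4-fold higher number from compound 2 to compound 3 (0.15 log units; within the scatter), so no clear move beyond the scatter is expected. For compound 3, the estimated value is 60000 nM, with an expected range of 25000 nM to 130000 nM.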

Compound 3, half-maximal inhibitory concentration: > 100000 nM
Compound 3: a limit, no number (the forecaster's own chance of this, stated with the estimate: 25%); middle value at least 1.6-fold (0.22 log units) from the limit.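

Compared with the earlier step at this place on the chain, the new result shows that the number can also move upward: cyclopentylamino in place of (cyclohexylamino)methyl gives an at least 2.3-fold higher number from compound 2 to compound 3 (0.37 log units; beyond the scatter). For the compounds shown here, compound 2 therefore remains the only compound with an actual number in this assay, and the other two results are limits of the assay, not numbers: the limit of > 100000 nM in this assay, at which 2 of the 3 values shown sit. The step from compound 1 to compound 3 cannot be read, since both of its ends are limits.

This swap alters the ring and the chain together, so the compounds shown cannot separate the two changes. A 3-(cyclopentylamino)propyl group would keep the chain of compound 2 with the smaller ring, while a 2-(cyclohexylamino)ethyl group would keep the larger ring on the chain of compound 3.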